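A few compounds are considered here, and "the series" means these few. Any claim that something is new, unique, unknown or untested is made for them only; others in the source may bear on it.

Series values in a functional assay on A549 cells (Homo sapiens) for cytotoxicity, with a stated time of 48 h; a higher number here means a weaker inhibitor, a lower number a stronger inhibitor:
- compound 1 `CCOc1ccc2oc(/C=C/[S+](C)[O-])cc(=O)c2c1`: 1500 nM
- compound 2 `CCCC(=O)Oc1ccc2oc(/C=C/[S+](C)[O-])cc(=O)c2c1`: 2200 nM

Compound 2, at 2200 nM, cannot be separated from compound 1, at 1500 nM, so the two values give no ordering. The next compound to be read in this assay is compound 3 `C[S+]([O-])/C=C/c1cc(=O)c2cc(F)ccc2o1`. Going from compound 2 to compound 3 is fluoro in place of (propylcarbonyl)oxy on an aromatic carbon, with the rest of the shared core unchanged.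

Among the measured compounds shown here, only one measured step bears on this change: a 1.5-fold higher number from compound 1 to compound 2 (0.17 log units; within the scatter). That step swaps propylcarbonyl for ethyl on the oxygen at this same place and stays within the scatter. For the measured compounds named here, it is weak evidence, since both measured compounds carry an oxygen here and no measured compound carries fluoro. A step beyond the scatter is therefore not expected, though the range is kept wide. The estimated step is a 1.2-fold lower number from compound 2 to compound 3 (0.09 log units; within the scatter). The expected value for compound 3 is 1800 nM, with an estimated range of 700 nM to 4500 nM.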

Compound 3, half-maximal inhibitory concentration: 2100 nM
Compound 3: middle estimate off by 1.2-fold (0.07 log units), on the low side; low and high end bracket the measured number.
By their numbers in this assay, from the lowest: compounds 1, 3 and 2 (each within the scatter of the next).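

In this assay, a 1.0-fold lower number from compound 2 to compound 3 (0.02 log units; within the scatter) and a 1.4-fold higher number from compound 1 to compound 3 (0.15 log units; within the scatter) are both within the scatter, so fluoro cannot be separated from either oxygen-linked group at this aromatic carbon. Among the compounds shown here, the earlier pair compared only two groups attached through oxygen; this result extends the flat reading to a substituent without that oxygen, and to a change from 6 heavy atoms in (propylcarbonyl)oxy to 1 in fluoro, leaving compounds 1, 2 and 3 without any ordering. No supporting measurement is available to explain this flat reading.

Whether an amine, a carboxylic acid or a longer chain at this aromatic carbon would give a step beyond the scatter remains open, as the three groups shown do not define any limit for the position. The shared core is also unchanged across compounds 1, 2 and 3, so the compounds shown do not reveal how changes elsewhere, such as replacing the side chain that carries the sulfur, would affect the read-out.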